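Replacing a benzyl ether with a methoxybenzoate ester

This account rests on a few compounds, and the source may have more. Where it says the series, first, only, none or still open, it means among the compounds named here.

Compound 1 `C#CCOc1ccc2c(=O)c(-c3cc(OC)c(OC)cc3OC)coc2c1`: > 10000 nM
Compound 2 `COc1cc(OC)c(-c2coc3cc(OCc4ccccc4)ccc3c2=O)cc1OC`: 9750 nM

Compound 1 gives only a limit in a functional assay on HUVEC cells (Homo sapiens) for antiproliferative activity, read by MTT assay, with a stated time of 24 h (on this read-out higher numbers stand for weaker inhibition and lower numbers for stronger inhibition), > 10000 nM. Compound 2 gives 9750 nM in this assay, the single number shown. The other value, that of compound 1, is a limit (the limit of > 10000 nM in this assay, at which 1 of the 2 values shown sits). Compound 3 `COc1cccc(C(=O)Oc2ccc3c(=O)c(-c4cc(OC)c(OC)cc4OC)coc3c2)c1` differs from compound 2 by (3-methoxyphenyl)carbonyl in place of benzyl on an oxygen on an aromatic ring. Going by the values given here, the one measured step, an at least 1.0-fold lower number from compound 1 to compound 2 (0.01 log units; that floor lies within the scatter), also exchanged the group on that oxygen and stayed within the scatter. No step involving an ester is shown, so the change is expected to give no step beyond the scatter, a 1.0-fold higher number from compound 2 to compound 3 (0.01 log units; within the scatter). Compound 3 is therefore estimated at 10000 nM, between 4000 nM and 25000 nM.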

Compound 3, half-maximal inhibitory concentration: > 10000 nM
Compound 3: a limit, no number; the forecaster's own chance of this, stated with the estimate: 50%; the middle value sits exactly at the limit.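

Compound 3 gives only a limit, not a number, in this assay: the limit of > 10000 nM in this assay, at which 2 of the 3 values shown sit. Exchanging benzyl for (3-methoxyphenyl)carbonyl on this oxygen gives an at least 1.0-fold higher number from compound 2 to compound 3 (0.01 log units; that floor lies within the scatter), so turning the ether into an ester brings no gain in inhibition here. The step between compound 1 and compound 3 joins two limits and cannot be read. The compounds shown leave open whether a chain ending in an amine or a carboxylic acid on this oxygen would bring the number down.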